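The source may hold more compounds than are shown below. What is called first, only, known or untested is meant among the compounds shown, and "the series" means these compounds.

Of the compounds shown here, two have been measured in a physicochemical assay for lipophilicity; a higher number here means a more lipophilic compound, a lower number a more polar compound. Compound 1, `CCOC(=O)C1=C(C)NC(=O)NC1c1cn(C(=O)CNc2ccc([N+](=O)[O-])cc2Cl)c2ccccc12`, gives 1.99. For the measured compounds named here, compound 2, `CCOC(=O)C1=C(C)NC(=O)NC1c1cn(C(=O)CNc2ccc([N+](=O)[O-])cc2)c2ccccc12`, gives 1.48, the lower of the two numbers, and the only measured step, a number 0.51 log units lower from compound 1 to compound 2 (beyond the scatter), separates them. Compound 3, `CCOC(=O)C1=C(C)NC(=O)NC1c1cn(C(=O)CNc2ccc(Cl)cc2)c2ccccc12`, has not been measured yet. It differs from compound 2 in one place: chloro in place of nitro on an aromatic carbon. Going by the values given here, no measured pair shows this exact exchange, so the one available step serves as the nearest guide: removing a chloro in going from compound 1 to compound 2 lowered the partition coefficient modestly, and compound 3 gains a chloro while giving up a nitro. The expectation for this assay is therefore a rise from compound 2 to compound 3 of about a number 0.82 log units higher from compound 2 to compound 3 (beyond the scatter), beyond the scatter. Compound 3 is accordingly estimated at 2.3, within a range from 1.8 to 2.8.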

Compound 3, partition coefficient: 2.04
Compound 3: middle estimate off by 0.26 log units, on the high side, within the range that was stated.
By their numbers in this assay, from the lowest: compound 2; then compounds 1 and 3 (each within the scatter of the next).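

Placing chloro instead of nitro on the aromatic carbon para to a large group gives, in this assay, a number 0.56 log units higher from compound 2 to compound 3 (beyond the scatter) as the first measured change at this position. The comparison of the two aryl groups on the amine nitrogen gives a number 0.05 log units higher from compound 1 to compound 3 (within the scatter) and so does not separate 4-chlorophenyl from 2-chloro-4-nitrophenyl in this read-out, even though the two groups differ in whether they carry a nitro. Nothing measured here offers an explanation for either step.

From the compounds shown here alone, whether an amine, a carboxylic acid or a methoxy group at this position would give a number closer to that of compound 2 or compound 3 remains open. Also open, going by these compounds, is whether exchanging nitro for chloro would give a step of similar size on a ring that already carries a second chloro.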